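The source may report more compounds than this note shows. Statements on the series, on what has been measured and on what is new or still open speak of the compounds shown alone.

Measured so far:
compound 1 `CC(=O)OC/C(=C\C1CCCCC1)C(=O)c1ccc(Cl)cc1` — 31000 nM
compound 2 `CC(=O)OC/C(=C/c1ccccc1Br)C(=O)c1ccccc1` — 21000 nM
compound 3 `C=C(C/C(=C\c1ccccc1)C(=O)c1ccccc1)C(=O)c1ccccc1` — 10000 nM

In a functional assay on HBL-100 cells (Homo sapiens) for inhibition, read by sulforhodamine B assay, with a stated time of 48 h (a higher number here means a weaker inhibitor of growth, a lower number a stronger inhibitor of growth), compound 3 stands lowest of the three numbers. The nearest is compound 2, whose value lies beyond the scatter above it, and the furthest is compound 1, further above again. Compound 3 therefore is the strongest growth inhibitor of the three, though the gaps are not large.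

The next compound, compound 4 `C=C(C/C(=C\c1ccc(OC)cc1)C(=O)c1ccccc1)C(=O)c1ccccc1`, keeps the whole of compound 3 and changes one point: methoxy in place of hydrogen on an aromatic carbon, on the six-membered aromatic ring of carbon only that carries the alkene. For the measured compounds named here, no measured pair in this set shows the same change, so the size of the step in this assay has no precedent here; a modest step in either direction, or none beyond the scatter, is plausible. Compound 3 is held as the anchor because its value in this assay is 10000 nM, and the step is expected to be small.

The estimated step is a 1.3-fold lower number from compound 3 to compound 4 (0.10 log units; within the scatter). Compound 4 is expected to give 8000 nM in this assay, with a range from 3000 nM to 25000 nM.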

Compound 4, concentration for 50% growth inhibition: 530 nM
Estimate against measurement, compound 4: 15-fold (1.18 log units) above; measured number outside the range, below it.
By their numbers in this assay, from the lowest: compound 4; then compound 3; then compounds 2 and 1 (each within the scatter of the next).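

Phenyl to 4-methoxyphenyl is the first change in the series that can be read at a single place, and in this assay it gives a 19-fold lower number from compound 3 to compound 4 (1.28 log units; beyond the scatter). For the compounds shown here, no earlier pair differs in one place, so the earlier compounds gave no reading of this aromatic carbon, para to a large group; it now proves to be a position where one small substituent can shift the number well beyond the scatter. No measurement at hand accounts for the size of this step.

On these data alone, it remains open whether the step belongs to methoxy itself or would also follow from another group on this carbon, such as hydroxy, ethoxy, fluorine or a dimethylamino group, and whether methoxy on other carbons of the same ring would give a step of similar size. Also open, as far as these compounds go, is whether the same change would carry over to the acetate-bearing cores of compound 1 and compound 2, since this single step rests on the core of compound 3 alone.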